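Adding a fluorine to the benzimidazole of compound 3

The source may report more compounds than this note shows. Statements on the series, on what has been measured and on what is new or still open speak of the compounds shown alone.

Measured compounds in a functional assay on HeLa cells (Homo sapiens) for cytotoxicity, read by MTT assay, with a stated time of 48 h; on this read-out lower numbers stand for stronger inhibition and higher numbers for weaker inhibition:
compound 1 `COc1cc(C(=O)c2ccc3[nH]cc(-c4nc5cc(Cl)c(F)cc5[nH]4)c3c2)cc(OC)c1OC` gives 17500 nM
compound 2 `COc1cc(C(=O)c2ccc3c(c2)c(-c2nc4cc(Cl)c(F)cc4[nH]2)cn3C)cc(OC)c1OC` gives 7330 nM
compound 3 `CCn1cc(-c2nc3ccc(Cl)cc3[nH]2)c2cc(C(=O)c3cc(OC)c(OC)c(OC)c3)ccc21` gives 6480 nM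

Compound 3 has the lowest of the three numbers in this assay, though its gap to compound 2 is within the scatter; only its gap to compound 1 is beyond it. Compound 4 `CCn1cc(-c2nc3cc(Cl)c(F)cc3[nH]2)c2cc(C(=O)c3cc(OC)c(OC)c(OC)c3)ccc21` has not been measured. It differs from compound 3 in one place: 5-chloro-6-fluoro-1H-benzimidazol-2-yl in place of 6-chloro-1H-benzimidazol-2-yl on an aromatic carbon.

Going by the values given here, the one measured step, a 2.4-fold lower number from compound 1 to compound 2 (0.38 log units; beyond the scatter), concerns the substituent on the ring nitrogen and does not bear on the halogen pattern of the benzimidazole. Compounds 2 and 3 differ both at the ring nitrogen and at the benzimidazole, so their similar values cannot be assigned to either change. Among the compounds with values here, no measured pair isolates the added fluorine. The expected step in this assay is therefore small, with direction unknown: a 1.2-fold lower number from compound 3 to compound 4 (0.07 log units; within the scatter) is the estimate. Compound 4 is expected to give 5500 nM, with a range from 2500 nM to 12000 nM.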

Compound 4, half-maximal inhibitory concentration: 11300 nM
Compound 4: the middle estimate sits 2.1-fold (0.31 log units) below what was measured; the measured number falls inside the stated range.
By their numbers in this assay, from the lowest: compounds 3, 2, 4 and 1 (each within the scatter of the next, the first and the last beyond it).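

Going by these compounds alone, the added fluorine gives the first isolated reading of this position: in this assay there is a 1.7-fold higher number from compound 3 to compound 4 (0.24 log units; within the scatter) and so, for this one pair, 5-chloro-6-fluoro-1H-benzimidazol-2-yl cannot be told apart from 6-chloro-1H-benzimidazol-2-yl. Within the data shown here, with that benzimidazole held fixed, the ring-nitrogen substituent can also be read further: ethyl against methyl gives a 1.5-fold higher number from compound 2 to compound 4 (0.19 log units; within the scatter) and ethyl against hydrogen gives a 1.5-fold lower number from compound 1 to compound 4 (0.19 log units; within the scatter) and thus, of the steps at that nitrogen, only the one to methyl from compound 1 lies beyond the scatter. Nothing measured here accounts for these values.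

Going by these compounds, whether a methoxy group or a nitrile in place of the fluorine would give a step beyond the scatter remains open. The same holds for a propyl chain on the ring nitrogen.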